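A few compounds are considered here, and "the series" means these few. Any claim that something is new, unique, unknown or untested is made for them only; others in the source may bear on it.

Among the compounds with values here, in a functional assay on Raji cells (Homo sapiens) for antiproliferative activity, read by MTT assay, with a stated time of 6 days (on this read-out higher numbers stand for weaker inhibition and lower numbers for stronger inhibition), three compounds have numbers so far. Compound 1 `CC(=O)O[C@@H]1C=CC(=O)O[C@@H]1[C@@H](COC(=O)c1ccc(Cl)cc1)OC(C)=O` gives 1850 nM, compound 2 `CC(=O)O[C@@H]1C=CC(=O)O[C@@H]1[C@@H](COC(=O)c1ccc([N+](=O)[O-])cc1)OC(C)=O` gives 18500 nM, and compound 3 `O=C1C=C[C@@H](OCc2ccccc2)[C@@H]([C@@H](COC(=O)/C=C/c2ccccc2)OCc2ccccc2)O1` gives 1330 nM. Compound 3 carries the lowest of these three numbers; its nearest neighbour is compound 1, which lies within the scatter of it, while compound 2 stands furthest away, beyond the scatter.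

Compound 4 `O=C1C=C[C@@H](OCc2ccccc2)[C@@H]([C@@H](COC(=O)/C=C/c2ccc([N+](=O)[O-])cc2)OCc2ccccc2)O1` differs from compound 3 in a single place: nitro in place of hydrogen on an aromatic carbon. Within the data shown here, only one measured step bears on this change, namely a 10-fold higher number from compound 1 to compound 2 (1.00 log units; beyond the scatter), in which a nitro group also entered a six-membered aromatic ring of carbon only, though there it displaced a chloro group on a benzoate rather than a hydrogen on a 2-phenylethenyl group. That step points to a higher number, and hence weaker inhibition, once nitro is present.

Among the measured compounds shown here, compound 4 carries the same entering group on a different ring, and its number in this assay is expected to rise over that of compound 3 by a smaller amount than the one measured step showed. The expected step is a 4.5-fold higher number from compound 3 to compound 4 (0.65 log units; beyond the scatter). Compound 4 is accordingly estimated at 6000 nM, with a range from 2000 nM to 20000 nM.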

Compound 4, half-maximal inhibitory concentration: 140 nM
Estimate against measurement, compound 4: 43-fold (1.63 log units) above, outside the stated range (below it).
By their numbers in this assay, from the lowest: compound 4; then compounds 3 and 1 (each within the scatter of the next); then compound 2.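

In this assay, nitro in place of hydrogen on an aromatic carbon, para to a large group, gives a 9.5-fold lower number from compound 3 to compound 4 (0.98 log units; beyond the scatter). The earlier step, a 10-fold higher number from compound 1 to compound 2 (1.00 log units; beyond the scatter), also brought in a nitro group but ran the opposite way, so across these two pairs nitro on a six-membered aromatic ring of carbon only does not move the number in one fixed direction. The two steps differ both in the group that leaves, chloro in one and hydrogen in the other, and in the compounds that carry the change, and nothing measured here explains why the direction reverses.

The compounds shown leave open whether the lower number is particular to nitro or would also follow from another group on the same aromatic carbon, such as an amine, a methoxy group or a chloro group. They also leave open what nitro in place of hydrogen would do on the aromatic ring of compound 1, which would show whether the reversal follows the group that leaves or the compound that carries the change.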